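Replacing a ring substituent with isopropyl on a flat cytotoxicity baseline

The source may hold more compounds than are shown below. What is called first, only, known or untested is meant among the compounds shown, and "the series" means these compounds.

Compound 1 `O=C(c1ccccc1)c1ccc2nc(NCCC3CCCNC3)[nH]c2c1`: in an ADME assay on HL-60 cells (Homo sapiens) for cytotoxicity, read by resazurin assay, with a stated time of 72 h (on this read-out lower numbers stand for an effect already at smaller amounts and higher numbers for an effect only at larger amounts of compound), compound 1 gives > 30000 nM, which is a limit of the assay and not a number.
Compound 2 `CN1CCC(Cn2c(N)nc3ccc(C(=O)c4ccccc4)cc32)CC1`: in this assay compound 2 gives > 30000 nM, again a limit of the assay rather than a number.

For the measured compounds named here, compound 2 therefore stands at the only place the measured values occupy so far: the limit of > 30000 nM in this assay, at which 2 of the 2 values shown sit. Going by the values given here, nothing measured yet distinguishes one compound from another in this assay, and no step between measured compounds is available to calibrate against.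

Compound 3 `CC(C)Cn1c(N)nc2ccc(C(=O)c3ccccc3)cc21` is the next compound to be measured. It differs from compound 2 in one place: isopropyl in place of 1-methylpiperidin-4-yl on a saturated chain carbon bound to an aromatic nitrogen. With both measured values sitting at the same limit, there is no measured change in this assay on which to base a direction. The step is expected to be a step that the limit leaves unreadable from compound 2 to compound 3, that is, no movement beyond the scatter, with compound 3 most likely remaining at the limit as well. Compound 3 is estimated at 40000 nM, with a range from 15000 nM to 100000 nM.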

Compound 3, half-maximal effective concentration: > 30000 nM
Compound 3: no number, only a limit; the forecaster's own chance of this, stated with the estimate: 75%; the middle value does not contradict the limit.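

For compound 2 and compound 3, both values are limits of the assay and not numbers, so no step can be read from the exchange of 1-methylpiperidin-4-yl for isopropyl. The compounds shown leave open whether any change on the shared core would produce a readable effect in this assay, since all stand at one place: the limit of > 30000 nM in this assay, at which 3 of the 3 values shown sit.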